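A pyridin-4-yl exchange on compound 2

This account rests on a few compounds, and the source may have more. Where it says the series, first, only, none or still open, it means among the compounds named here.

Measured in an ADME assay on Vero cells (Chlorocebus sabaeus) for cytotoxicity, read by sulforhodamine B assay, with a stated time of 3 days; on this read-out lower numbers stand for higher toxicity in this test and higher numbers for lower toxicity in this test:
Compound 1 (`COc1ccc(C2C(C(=O)Nc3ccc(Cl)cc3)=C(C)NC(C)=C2C(=O)Nc2ccc(Cl)cc2)cc1`): 20 ug/mL
Compound 2 (`COc1ccc(NC(=O)C2=C(C)NC(=O)NC2c2ccccc2O)cc1`): 160 ug/mL

Of these two, compound 2 holds the higher number, and the gap to compound 1 lies beyond the scatter. Compound 3 (`COc1ccc(NC(=O)C2=C(C)NC(=O)NC2c2ccncc2)cc1`) carries pyridin-4-yl in place of 2-hydroxyphenyl on a saturated ring carbon. Going by the values given here, no measured step covers this exchange, so the expectation starts from compound 2 at 160 ug/mL and foresees no change beyond the scatter in this assay, with a slight lean downward. The estimate means a 1.2-fold lower number from compound 2 to compound 3 (0.09 log units; within the scatter) as the expected step. For compound 3 the estimated value is 130 ug/mL, with an expected range from 50 ug/mL to 320 ug/mL.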

Compound 3, half-maximal cytotoxic concentration: 10 ug/mL
Compound 3: middle estimate off by 13-fold (1.11 log units), on the high side; the measured number lies below the stated range.
By their numbers in this assay, from the lowest: compounds 3 and 1 (each within the scatter of the next); then compound 2.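

In this assay, the group on the saturated ring carbon proves decisive: with the rest of compound 2 unchanged, pyridin-4-yl in place of 2-hydroxyphenyl gives a 16-fold lower number from compound 2 to compound 3 (1.20 log units; beyond the scatter), so this one position alone can move the number well beyond the scatter. Nothing measured here accounts for the size of this step. The compounds shown leave open whether the departing hydroxyl or the entering ring nitrogen carries the step, and an unsubstituted phenyl on this carbon would separate the two. From the compounds shown here alone, how a pyridin-3-yl would stand there also remains open.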